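This account rests on a few compounds, and the source may have more. Where it says the series, first, only, none or still open, it means among the compounds named here.

Of the compounds shown here, three have been measured so far.
Compound 1 `COc1ccc(CN(C(=O)CCCl)c2cc(OC)c(OC)c(OC)c2)cc1O` gives 110 nM in a functional assay on KYSE-450 cells (Homo sapiens) for inhibition, read by MTT assay, with a stated time of 48 h; a higher number here means a weaker inhibitor, a lower number a stronger inhibitor.
Compound 2 `COc1ccc(CNc2cc(OC)c(OC)c(OC)c2)cc1N` gives 2210 nM in this assay.
Compound 3 `COc1ccc(CNc2cc(OC)c(OC)c(OC)c2)cc1Cl` gives 47800 nM in this assay.

Compound 1 has the lowest number of the three, and both steps away from it are beyond the scatter, so it is the strongest inhibitor measured here; compound 2 stands nearest to it and compound 3 furthest. Among the compounds with values here, the only step between two measured compounds that differ in one place is a 22-fold higher number from compound 2 to compound 3 (1.34 log units; beyond the scatter), a change on an aromatic carbon of the benzyl ring. Compound 4 `C/C=C/C(=O)N(Cc1ccc(OC)c(O)c1)c1cc(OC)c(OC)c(OC)c1` differs from compound 1 elsewhere: prop-1-en-1-yl in place of 2-chloroethyl on a carbonyl carbon. Within the data shown here, no measured pair alters the group on the carbonyl carbon, and compounds 2 and 3 carry no such carbonyl group at all, so that measured step gives no guidance on this change. With the shared core of compound 1 otherwise untouched and a group of similar size entering, the expectation is for no step beyond the scatter, though the range must stay wide. Compound 4 is therefore estimated to give 200 nM, between 50 nM and 800 nM. The expected step is a 1.8-fold higher number from compound 1 to compound 4 (0.26 log units; within the scatter).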

Compound 4, half-maximal inhibitory concentration: 67 nM
The estimate for compound 4 lay 3.0-fold (0.47 log units) above the measured number; measured number inside the range.
By their numbers in this assay, from the lowest: compounds 4 and 1 (each within the scatter of the next); then compound 2; then compound 3.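

In this assay, prop-1-en-1-yl in place of 2-chloroethyl on a carbonyl carbon gives a 1.6-fold lower number from compound 1 to compound 4 (0.22 log units; within the scatter), so the two groups cannot be told apart at this position. The chlorine of the 2-chloroethyl group is therefore not required for a low number here: compound 4 has no chlorine and gives 67 nM in this assay. Nothing at hand explains why these two groups read alike.

From the compounds shown here alone, it remains open whether the double bond of prop-1-en-1-yl matters, which a saturated propyl group on the same carbonyl carbon could test. How far this position tolerates other groups is also unknown, for example a longer chain, a phenyl ring, or a chain carrying an amine or a carboxylic acid.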